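This account rests on a few compounds, and the source may have more. Where it says the series, first, only, none or still open, it means among the compounds named here.

Measured compounds:
- compound 1, `CCCCCCCC1C(CO[C@@H]2O[C@@H]3CO[C@H](c4ccccc4)O[C@@H]3[C@H](OCc3ccccc3)[C@H]2O)N1S(=O)(=O)c1ccc(C)cc1`: > 1000000 nM
- compound 2, `CCCC1(CO[C@@H]2O[C@@H]3CO[C@H](c4ccccc4)O[C@@H]3[C@H](OCc3ccccc3)[C@H]2OCc2ccccc2)CN1S(=O)(=O)c1ccc(C)cc1`: 793000 nM

In an ADME assay on MRC5 cells (Homo sapiens) for cytotoxicity, read by MTT assay, with a stated time of 48 h (on this read-out lower numbers stand for stronger inhibition and higher numbers for weaker inhibition), compound 1 gives > 1000000 nM, which is a limit of the assay and not a number. In this assay, within the data shown here, compound 2 gives 793000 nM, the only actual number in the set. The other value, that of compound 1, is a limit (the limit of > 1000000 nM in this assay, at which 1 of the 2 values shown sits). Compound 3, `Cc1ccc(S(=O)(=O)N2CC2(CO[C@@H]2O[C@@H]3CO[C@H](c4ccccc4)O[C@@H]3[C@H](OCc3ccccc3)[C@H]2OCc2ccccc2)c2ccccc2)cc1`, differs from compound 2 by phenyl in place of propyl on a saturated ring carbon. Among the measured compounds shown here, no step between measured compounds is available to gauge this change. Both measured entries sit at very weak inhibition, so the expected step from compound 2 to compound 3 in this assay is none beyond the scatter, a 1.0-fold higher number from compound 2 to compound 3 (0.00 log units; within the scatter). Compound 3 is expected at 800000 nM, within 300000 nM to 2000000 nM, with a fair chance that only a limit is reported.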

Compound 3, half-maximal inhibitory concentration: 570000 nM
For compound 3 the middle estimate is 1.4-fold (0.15 log units) above the measured one; measured number inside the range.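

In this assay, phenyl in place of propyl on a saturated ring carbon of the three-membered non-aromatic ring with 1 nitrogen gives a 1.4-fold lower number from compound 2 to compound 3 (0.14 log units; within the scatter). At this position, therefore, an aromatic ring of carbon only and an open carbon chain read alike in this cytotoxicity assay, and compound 3 gives a number rather than a limit. Compound 1 remains the only entry at a limit of the assay, which is not a number: the limit of > 1000000 nM in this assay, at which 1 of the 3 values shown sits.

The comparison at this carbon rests on a single step between two carbon-only groups, neither of which carries a hydrogen-bond donor or acceptor. As far as these compounds go, whether an amine, a carboxylic acid or a longer chain here would move the value in this assay beyond the scatter remains open.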